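The source may hold more compounds than are shown below. What is called first, only, known or untested is meant among the compounds shown, and "the series" means these compounds.

Compound 1 `CSC1NC(=O)n2cnc(Cc3ccc(C)cc3)c2N1` and compound 2 `Cc1ccc(CSC2NC(=O)n3cnc(Cc4ccc(C)cc4)c3N2)cc1` share one core; compound 3 `CSc1ncnc2c(Cc3ccc(C)cc3)ncn12` and compound 4 `Cc1ccc(CSc2ncnc3c(Cc4ccc(C)cc4)ncn23)cc1` share another. The difference between the two cores is not broken down here. In a functional assay on CCRF-CEM cells (Homo sapiens) for cytotoxicity (on this read-out higher numbers stand for lower toxicity in this test and lower numbers for higher toxicity in this test), compound 1 gives 75300 nM, and in this assay compound 2 gives 44600 nM. The change between them, (4-methylphenyl in place of hydrogen on a saturated chain carbon bound to a sulfur), made a step of a 1.7-fold lower number from compound 1 to compound 2 (0.23 log units; within the scatter). In this assay compound 3 gives 389000 nM, the highest number of the three measured compounds, beyond the scatter from both compound 1 and compound 2.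

Compound 4 carries the same change as compound 2, on the core of compound 3: 4-methylphenyl in place of hydrogen on a saturated chain carbon bound to a sulfur. This change has been seen once so far, and that step stayed within the scatter. Among the measured compounds shown here, nothing in the measured pairs shows the change acting differently on the second core, but nothing shows it acting the same either; the expectation rests on the single pair alone. The step from compound 3 to compound 4 is therefore expected at a 1.7-fold lower number from compound 3 to compound 4 (0.23 log units; within the scatter), beside the earlier 1.7-fold lower number from compound 1 to compound 2 (0.23 log units; within the scatter). Compound 4 is estimated in this assay at 230000 nM, with a range from 110000 nM to 480000 nM.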

Compound 4, half-maximal cytotoxic concentration: > 111000 nM
Compound 4 gave a limit, no number; the forecaster's own chance of this, stated with the estimate: 25%; the middle value lies beyond the limit too.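

In this assay compound 4 gives > 111000 nM as a limit, not a number. Among the compounds shown here, no step from compound 3 to compound 4 can be read from it. The compounds shown leave open whether 4-methylphenyl in place of hydrogen on a saturated chain carbon bound to a sulfur acts on the core of compound 3 as it does on the core of compound 1.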